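Pyridylethyl in place of phenyl on the hydroxy chain

A few compounds are considered here, and "the series" means these few. Any claim that something is new, unique, unknown or untested is made for them only; others in the source may bear on it.

Compound 3, with structure `CC(C)(C)C1=C(C(=O)O)N2C(=O)[C@H]([C@H](O)c3ccccc3)[C@@H]2O1`, sits at the bottom of the three numbers measured in an ADME assay, in phosphate buffer, at 28 degrees C, at pH 7.0 (a lower number here means that the compound disappears faster, a higher number that the compound lasts longer), giving 0.5 h. Going by the values given here, its nearest neighbour is compound 2, with structure `C[C@@H](O)[C@H]1C(=O)N2C(C(=O)O)=C(C(C)(C)C)O[C@@H]12`, which gives 6.4 h, and the only single-point step in the set, a 13-fold lower number from compound 2 to compound 3 (1.11 log units; beyond the scatter), is the replacement that leads to compound 3. Compound 1, with structure `CC(C)(C)C1=C(C(=O)O)N2C(=O)[C@H]([C@H](O)CCc3ccncc3)[C@H]2O1`, gives 13.7 h. The unmeasured compound 4, with structure `CC(C)(C)C1=C(C(=O)O)N2C(=O)[C@H]([C@H](O)CCc3ccncc3)[C@@H]2O1`, differs from compound 3 by 2-(pyridin-4-yl)ethyl in place of phenyl on a saturated chain carbon bound to an oxygen on a saturated carbon and a saturated ring carbon. The step bearing on this change is a 13-fold lower number from compound 2 to compound 3 (1.11 log units; beyond the scatter), which shows that removing the phenyl from that position is associated with a large shift upward in this assay; compound 1 carries the same 2-(pyridin-4-yl)ethyl group and shows a similarly high half-life. Compound 4 is therefore expected to gain substantially, by about a 16-fold higher number from compound 3 to compound 4 (1.20 log units; beyond the scatter). The estimated half-life of compound 4 is 8 h, with a range from 3 h to 20 h.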

Compound 4, half-life: 7.1 h
For compound 4 the middle estimate is 1.1-fold (0.05 log units) above the measured one; low and high end bracket the measured number.
By their numbers in this assay, from the lowest: compound 3; then compounds 2, 4 and 1 (each within the scatter of the next, the first and the last beyond it).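

In this assay, 2-(pyridin-4-yl)ethyl in place of phenyl at this position gives a 14-fold higher number from compound 3 to compound 4 (1.15 log units; beyond the scatter), so among these compounds the short half-life goes with phenyl and not with the shared core. Compound 4 cannot be told apart from compound 2, which carries a methyl there (a 1.1-fold higher number from compound 2 to compound 4 (0.05 log units; within the scatter)), so phenyl alone stands apart among the three groups. Inverting the ring stereocentre, drawn R in compound 1 and S in compound 4, also stays within the scatter (a 1.9-fold lower number from compound 1 to compound 4 (0.29 log units; within the scatter)), and this pair isolates that one feature: the fact that compounds 1 and 4 differ only in the configuration as drawn.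

Still open, as far as these compounds go, is whether the longer chain or the ring nitrogen goes with the longer half-life; 2-phenylethyl or pyridin-4-yl at this position would separate the two. Also open, from the compounds shown here alone, is whether a phenyl compound drawn R at that ring carbon would match compound 3.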